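From Hydroxy to Ethoxycarbonyl on Compound 2

The source may report more compounds than this note shows. Statements on the series, on what has been measured and on what is new or still open speak of the compounds shown alone.

Compound 2 `CC(C)(C)c1ccc(C(=O)N2CCC3(CC2)C(=O)N(CC(=O)N2CCC(O)CC2)CN3c2ccccc2)cc1` gives the lowest of the two numbers in hand. In an assay on HEK293 cells for displacement of a labelled ligand from NPC1-like intracellular cholesterol transporter 1 (Homo sapiens) (on this read-out higher numbers stand for weaker inhibition and lower numbers for stronger inhibition), compound 2 gives 4700 nM, whereas compound 1 `CC(C)(C)c1ccc(C(=O)N2CCC3(CC2)C(=O)N(CC(=O)NCCC(=O)O)CN3c2ccccc2)cc1` gives 11400 nM. Among the compounds with values here, the only measured step, a 2.4-fold lower number from compound 1 to compound 2 (0.38 log units; beyond the scatter), swapped the whole group on the carbonyl carbon: 4-hydroxypiperidin-1-yl in place of (2-carboxyethyl)amino.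

Compound 3 `CCOC(=O)C1CCN(C(=O)CN2CN(c3ccccc3)C3(CCN(C(=O)c4ccc(C(C)(C)C)cc4)CC3)C2=O)CC1` keeps that carbonyl and its piperidine and changes a single substituent: ethoxycarbonyl in place of hydroxy on a saturated ring carbon. Within the data shown here, no measured pair exchanges these two groups, so the step from compound 1 to compound 2 bears on it only in that it shows the group on this carbonyl is where the two known numbers separated, by a modest margin. The new change touches the same group but neither removes nor adds the acid of compound 1, and nothing in hand tells in which direction an ethoxycarbonyl would move the number. Compound 3 is therefore expected to give about 4000 nM, with a range from 1500 nM to 11000 nM. The step of a 1.2-fold lower number from compound 2 to compound 3 (0.07 log units; within the scatter) is estimated to stay within the scatter, the estimate resting on compound 2 standing at 4700 nM.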

Compound 3, half-maximal inhibitory concentration: 3100 nM
Compound 3: middle estimate off by 1.3-fold (0.11 log units), on the high side; low and high end bracket the measured number.
By their numbers in this assay, from the lowest: compounds 3 and 2 (each within the scatter of the next); then compound 1.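

At the saturated ring carbon three ring bonds from the ring nitrogen, this assay does not separate ethoxycarbonyl, with 5 heavy atoms and 0 hydrogen-bond donors, from hydroxy, with 1 heavy atom and 1 hydrogen-bond donor: the result is a 1.5-fold lower number from compound 2 to compound 3 (0.18 log units; within the scatter), so the larger group and the smaller one cannot be told apart on this read-out. The position therefore accepts this exchange without a change that can be read, which the earlier pair, differing in the whole group on the carbonyl carbon, could not show. Set against (2-carboxyethyl)amino on that carbonyl carbon, 4-(ethoxycarbonyl)piperidin-1-yl also stands clear, with a 3.7-fold lower number from compound 1 to compound 3 (0.57 log units; beyond the scatter), so two different piperidine groups now give lower numbers than that open chain.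

On these data alone, it remains open whether a carboxylic acid on the same ring carbon would bring the number back towards that of compound 1, which would tell the acid apart from the open chain that carries it. As far as these compounds go, it is equally open whether an amine or a longer ester chain there would stay within the scatter of compound 2. No measurement in hand offers an explanation for these numbers.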